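Swapping the acid of compound 2 for a pyrrolidine

The compounds below may be only part of what the source reports. "The series", "measured", "known", "first", "only" and "open" are said of these compounds alone.

Compound 1 `Cn1ncc(Cl)c1-c1cc(C(=O)N[C@H]2CNCC[C@@H]2c2ccc(C(F)(F)F)cc2)oc1Cl` — 127 nM
Compound 2 `Cn1ncc(Cl)c1-c1cc(C(=O)N[C@@H]2CN[C@H](CC(=O)O)C[C@H]2c2ccc(Cl)c(Cl)c2)oc1Cl` — 1.94 nM

Of the compounds shown here, two have so far been measured in an assay for inhibition of RAC-alpha serine/threonine-protein kinase (Homo sapiens), read by HTRF, with a stated time of 1 h; a higher number here means a weaker inhibitor, a lower number a stronger inhibitor. Compound 1 (`Cn1ncc(Cl)c1-c1cc(C(=O)N[C@H]2CNCC[C@@H]2c2ccc(C(F)(F)F)cc2)oc1Cl`) gives 127 nM, whereas compound 2 (`Cn1ncc(Cl)c1-c1cc(C(=O)N[C@@H]2CN[C@H](CC(=O)O)C[C@H]2c2ccc(Cl)c(Cl)c2)oc1Cl`) gives 1.94 nM, the lower of the two numbers and well beyond the scatter from compound 1. This account follows the change from compound 2 to compound 3 (`Cn1ncc(Cl)c1-c1cc(C(=O)N[C@@H]2CN[C@H](CCN3CCCC3)C[C@H]2c2ccc(Cl)c(Cl)c2)oc1Cl`), which has not yet been measured. The difference between the two is (pyrrolidin-1-yl)methyl in place of carboxy on a saturated chain carbon bound to a saturated ring carbon. Within the data shown here, no measured pair shows an exchange of this kind, so the size of the step cannot be read from the data. Because compound 2 already gives 1.94 nM and the shared core is untouched, the step from compound 2 to compound 3 is expected to be small, at most a loss near the edge of the scatter, a 1.8-fold higher number from compound 2 to compound 3 (0.26 log units; within the scatter). Compound 3 is expected to give about 3.5 nM, within a range from 1 nM to 12 nM.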

Compound 3, half-maximal inhibitory concentration: 6.41 nM
Compound 3: middle estimate off by 1.8-fold (0.26 log units), on the low side, within the range that was stated.
By their numbers in this assay, from the lowest: compound 2; then compound 3; then compound 1.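

In this assay, among these compounds, the exchange of carboxy for (pyrrolidin-1-yl)methyl on a saturated chain carbon bound to a saturated ring carbon gives the first readable step at this position, a 3.3-fold higher number from compound 2 to compound 3 (0.52 log units; beyond the scatter), a modest change beyond the scatter. The carboxy group is therefore not required for a low number here: compound 3, with 6 heavy atoms and a five-membered non-aromatic ring in the entering group, still gives 6.41 nM. No measurement available here explains why the number rises.

This single step does not separate the effect of removing carboxy from that of adding the pyrrolidine ring. It also leaves open how a dimethylamino group, a morpholine ring, a primary amine or a longer chain would read at the same place.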